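The source may hold more compounds than are shown below. What is called first, only, known or untested is meant among the compounds shown, and "the series" means these compounds.

Within the data shown here, compound 2 `COc1ccc(-c2cc(-c3ccc(C(=O)N(C)C)cc3)cnc2N)cn1` is one of two compounds measured so far in a physicochemical assay for lipophilicity, at pH 7.4 (on this read-out higher numbers stand for higher lipophilicity and lower numbers for lower lipophilicity), and in this assay compound 2 gives 2.1. Compound 1 `COc1ccc(-c2cc(-c3ccc(NS(C)(=O)=O)cc3)cnc2N)cn1` gives 2.2 in this assay, and the step of a number 0.10 log units lower from compound 1 to compound 2 (within the scatter) stays within the scatter, so the two numbers cannot be told apart. Compound 3 `CNC(=O)c1ccc(-c2cnc(N)c(-c3ccc(OC)nc3)c2)cc1` differs from compound 2 by hydrogen in place of methyl on an amide-type nitrogen. Among the measured compounds shown here, no measured step touches this amide-type nitrogen, so the expectation rests on the change alone. Compound 3 is expected to give about 1.7, within a range from 1.3 to 2.1. The expected step is a number 0.40 log units lower from compound 2 to compound 3 (beyond the scatter).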

Compound 3, distribution coefficient: 1.8
Estimate against measurement, compound 3: 0.10 log units below; measured number inside the range.
By their numbers in this assay, from the lowest: compounds 3, 2 and 1 (each within the scatter of the next, the first and the last beyond it).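

Hydrogen in place of methyl on the amide-type nitrogen gives the first reading at this position in this assay: a step of a number 0.30 log units lower from compound 2 to compound 3 (within the scatter), so this change alone cannot be told apart from repeat scatter. Methylcarbamoyl in place of methanesulfonamido on the aromatic carbon gives a number 0.40 log units lower from compound 1 to compound 3 (beyond the scatter), the first step in this series to pass the scatter, though only modestly. From the compounds shown here alone, what an ethyl group or longer chain on this nitrogen, or a carboxylic acid in place of the whole amide, would read remains open. No supporting evidence gives a reason for either step.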